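A few compounds are considered here, and "the series" means these few. Any claim that something is new, unique, unknown or untested is made for them only; others in the source may bear on it.

Measured so far:
Compound 1 `COc1ncnc2c1c(-c1ccccc1)cn2[C@@H]1O[C@H](CO)[C@@H](O)[C@H]1O`: > 20000 nM
Compound 2 `CSc1ncnc2c1c(-c1ccoc1)cn2[C@@H]1O[C@H](CO)[C@@H](O)[C@H]1O`: 360 nM

Among the compounds with values here, in a functional assay on HL-60 cells (Homo sapiens) for antiproliferative activity, read by XTT assay, with a stated time of 72 h (on this read-out lower numbers stand for stronger inhibition and higher numbers for weaker inhibition), compound 2 gives 360 nM, the only actual number available so far. The reading for compound 1 is > 20000 nM, which is a limit of the assay and not a number.

Compound 3 `CSc1ncnc2c1c(-c1cccs1)cn2[C@@H]1O[C@H](CO)[C@@H](O)[C@H]1O` has yet to be measured in this assay. It carries thiophen-2-yl in place of the furan-3-yl of compound 2, on an aromatic carbon of a five-membered aromatic ring with 1 nitrogen: thiophen-2-yl in place of furan-3-yl on an aromatic carbon. Each of the two groups is one five-membered aromatic ring with 1 hetero atom. Within the data shown here, no measured pair shows this change, so the expectation rests on compound 2 and its 360 nM alone. No shift beyond the usual scatter is expected in either direction, and the estimated change is a 1.1-fold lower number from compound 2 to compound 3 (0.05 log units; within the scatter). With so little to go on, the expected range is kept wide. For compound 3 the estimated value is 320 nM, expected to lie between 80 nM and 1500 nM.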

Compound 3, half-maximal inhibitory concentration: 1130 nM
Estimate against measurement, compound 3: 3.5-fold (0.55 log units) below, and the stated range covers the measured number.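

In this assay, the position on an aromatic carbon of a five-membered aromatic ring with 1 nitrogen proves sensitive to which ring it carries: thiophen-2-yl in place of furan-3-yl gives a 3.1-fold higher number from compound 2 to compound 3 (0.50 log units; beyond the scatter), a modest weakening that lies beyond the usual scatter. Within the data shown here, the earlier compounds offered no step at all, so this is the first sign that the choice of group here matters to the read-out. The counts stay the same, with each group being one five-membered aromatic ring with 1 hetero atom and 5 heavy atoms. Nothing shown here bears on the origin of the step.

Among these compounds, compound 1 differs from compound 2 in more than one place and adds no step. The reading of compound 1 is > 20000 nM, which is a limit and not a number. Going by these compounds, the exchange alters both the hetero atom and the point of attachment, so it remains open which of the two matters, and a thiophen-3-yl group at this position would separate them, while an amine or a longer chain there would show how far the position tolerates anything other than a small aromatic ring.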